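The compounds below may be only part of what the source reports. "The series", "measured", "known", "first", "only" and "open" are said of these compounds alone.

Series notes. Three compounds on a shared core carry different aryl groups on the amide nitrogen: compound 1 `O=C(COc1ccc2cc(/C=C3/SC(=O)NC3=O)ccc2c1)Nc1ccc(F)cc1F`, compound 2 `Cc1cc(Br)ccc1NC(=O)COc1ccc2cc(/C=C3/SC(=O)NC3=O)ccc2c1` and compound 3 `COc1ccc(NC(=O)COc2ccc3cc(/C=C4/SC(=O)NC4=O)ccc3c2)cc1`. In an assay on isolated protein for inhibition of histone deacetylase 4 (Homo sapiens), with a stated time of 1 h (on this read-out lower numbers stand for stronger inhibition and higher numbers for weaker inhibition), compound 1 gives 3900 nM, compound 2 gives 550 nM and compound 3 gives 4700 nM. Compound 2 stands lowest of the three, with both of its steps to the others beyond the scatter: a 7.1-fold lower number from compound 1 to compound 2 (0.85 log units; beyond the scatter) and an 8.5-fold higher number from compound 2 to compound 3 (0.93 log units; beyond the scatter). Compound 1 and compound 3 are within the scatter of each other, a 1.2-fold higher number from compound 1 to compound 3 (0.08 log units; within the scatter).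

Compound 4 `O=C(COc1ccc2cc(/C=C3/SC(=O)NC3=O)ccc2c1)Nc1ccc(Br)cc1` is not yet measured. It differs from compound 2 in one place: hydrogen in place of methyl on an aromatic carbon. Among the measured compounds shown here, no measured step isolates this change; the two steps that touch compound 2 each exchange the whole aryl group, so they give only a loose bound on what one methyl contributes. The bromo group of compound 2 is kept, so the number for compound 4 is expected to stay nearer to compound 2 than to compound 1 or compound 3, with a step of a 2.0-fold higher number from compound 2 to compound 4 (0.30 log units; within the scatter) expected, toward weaker inhibition but possibly within the scatter. For compound 4 in this assay the estimate is 1100 nM, with a range from 450 nM to 2800 nM.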

Compound 4, half-maximal inhibitory concentration: 2900 nM
Compound 4: the middle estimate sits 2.6-fold (0.42 log units) below what was measured; the whole stated range lies below it.
By their numbers in this assay, from the lowest: compound 2; then compounds 4, 1 and 3 (each within the scatter of the next).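

Methyl on this aromatic carbon, ortho to a large group and meta to the bromo group, is the change that separates compound 2 from the rest of the series: in this assay, its loss gives a 5.3-fold higher number from compound 2 to compound 4 (0.72 log units; beyond the scatter). The bromo group alone does not produce the low number of compound 2, since the remaining steps, a 1.6-fold lower number from compound 3 to compound 4 (0.21 log units; within the scatter) and a 1.3-fold lower number from compound 1 to compound 4 (0.13 log units; within the scatter), both stay within the scatter. No measured evidence bears on why this methyl matters.

The compounds shown leave open whether ethyl, chloro or an amine on the same aromatic carbon would go with a number as low as that of methyl. Among the compounds shown here, they also leave open whether methyl there has a similar step without the bromo group, as this single step is seen only with bromo present.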